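The source may report more compounds than this note shows. Statements on the series, on what has been measured and on what is new or still open speak of the compounds shown alone.

Measured so far in an ADME assay on HepG2 2.2.15 cells (Homo sapiens) for cytotoxicity, read by MTT assay; on this read-out higher numbers stand for lower toxicity in this test and lower numbers for higher toxicity in this test:
compound 1 `C=C1CC[C@@H]2[C@](C)(COC(=O)c3cccs3)[C@H](O)CC[C@@]2(C)[C@@H]1/C=C/C1=CCOC1=O`: 557000 nM
compound 2 `C=C1CC[C@@H]2[C@](C)(COC(=O)c3cccnc3)[C@H](O)CC[C@@]2(C)[C@@H]1C/C=C1\C=COC1=O`: 2050000 nM
compound 3 `C=C1CC[C@@H]2[C@](C)(COC(=O)c3cccs3)[C@H](O)CC[C@@]2(C)[C@@H]1C/C=C1\C=COC1=O`: 2470000 nM

Compound 3 cannot be told apart from compound 2 in this assay, and the numbers of both stand above that of compound 1. The measured step beyond the scatter is a 4.4-fold higher number from compound 1 to compound 3 (0.65 log units; beyond the scatter).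

Compound 4 `C=C1CC[C@@H]2[C@](C)(COC(C)=O)[C@H](O)CC[C@@]2(C)[C@@H]1C/C=C1\C=COC1=O` keeps the shared core of compound 3 and changes only the ester: methyl in place of thiophen-2-yl on a carbonyl carbon. In words, this is methyl in place of thiophen-2-yl on a carbonyl carbon, or (thiophen-2-yl)carbonyl to acetyl.

The closest measured step is a 1.2-fold higher number from compound 2 to compound 3 (0.08 log units; within the scatter). It exchanges the group on the same carbonyl carbon, pyridin-3-yl to thiophen-2-yl, and leaves the number within the scatter. The step from compound 1 concerns a different group, on a saturated ring carbon, so it says little about this change. Among the compounds with values here, no compound with a small non-aromatic group on that carbonyl has been measured, so the single relevant step is thin support and the range stays wide.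

No change beyond the scatter is therefore expected, and the estimated step is a 1.2-fold lower number from compound 3 to compound 4 (0.09 log units; within the scatter). For compound 4 the expected value is 2000000 nM, with an estimated range from 900000 nM to 4500000 nM.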

Compound 4, half-maximal cytotoxic concentration: 334000 nM
Beside the measured number, compound 4's estimate is 6.0-fold (0.78 log units) above it; the whole stated range lies above it.
By their numbers in this assay, from the lowest: compounds 4 and 1 (each within the scatter of the next); then compounds 2 and 3 (each within the scatter of the next).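

In this assay the group on the carbonyl carbon now proves able to move the number: methyl in place of thiophen-2-yl brings a 7.4-fold lower number from compound 3 to compound 4 (0.87 log units; beyond the scatter) and methyl in place of pyridin-3-yl brings a 6.1-fold lower number from compound 2 to compound 4 (0.79 log units; beyond the scatter) on the same carbonyl carbon. The earlier exchange between the two aromatic rings stayed within the scatter, so the position gave no sign of this sensitivity until the ring was replaced by methyl, and here the lower number stands for higher toxicity in this test. Nothing available explains the difference between methyl and the two aromatic rings.

The compounds shown leave open where between methyl and these rings the number turns, and a longer chain such as propyl, or a cyclohexyl or phenyl group on the same carbonyl carbon, would help separate the loss of the aromatic ring from the loss of heavy atoms. Also open, as far as these compounds go, is whether the same exchange gives a step of like size on the core of compound 1, and how an amine or a carboxylic acid carried on the ester chain would read.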